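Cathepsin S series: chloroindole to azaindole step

The source may report more compounds than this note shows. Statements on the series, on what has been measured and on what is new or still open speak of the compounds shown alone.

Measured so far:
compound 1, `Cn1c(=O)n(C2CCN(CCCn3nc(-c4ccc(Cl)c(Cl)c4)c4c3CCN(S(C)(=O)=O)C4)CC2)c2ccccc21`: 10 nM
compound 2, `COC(=O)c1sc2cc(F)ccc2c1C1CCN(CC(O)Cn2nc(-c3ccc(C(F)(F)F)cc3)c3c2CCN(S(C)(=O)=O)C3)CC1`: 130 nM
compound 3, `CS(=O)(=O)N1CCc2c(c(-c3ccc(C(F)(F)F)cc3)nn2CC(O)CN2CCC(c3c[nH]c4cc(Cl)ccc34)CC2)C1`: 29 nM

In an assay on isolated protein for inhibition of cathepsin S (Homo sapiens) (a lower number here means a stronger inhibitor, a higher number a weaker inhibitor), compound 3 stands second highest of the three numbers; compound 1 gives the lower number and compound 2 the higher one, both gaps beyond the scatter. Compound 4, `CS(=O)(=O)N1CCc2c(c(-c3ccc(C(F)(F)F)cc3)nn2CC(O)CN2CCC(c3c[nH]c4ccncc34)CC2)C1`, differs from compound 3 in one place: a group of 9 heavy atoms (7 carbon, 2 nitrogen; one five-membered aromatic ring with 1 hetero atom, one six-membered aromatic ring with 1 hetero atom) in place of a group of 10 heavy atoms (8 carbon, 1 nitrogen, 1 chlorine; one five-membered aromatic ring with 1 hetero atom, one six-membered aromatic ring of carbon only), on a saturated ring carbon. The chlorine goes and a ring nitrogen arrives. Among the measured compounds shown here, no step between measured compounds covers this change, so the expectation rests on the change alone. A weaker inhibitor is expected, a rise clearly beyond the scatter; the step is estimated as a 3.1-fold higher number from compound 3 to compound 4 (0.49 log units; beyond the scatter). Compound 4 is expected at 90 nM in this assay, within a range from 30 nM to 300 nM.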

Compound 4, half-maximal inhibitory concentration: 58 nM
Estimate against measurement, compound 4: 1.6-fold (0.19 log units) above, and the stated range covers the measured number.
By their numbers in this assay, from the lowest: compound 1; then compounds 3 and 4 (each within the scatter of the next); then compound 2.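

On a saturated ring carbon of the six-membered ring with 1 nitrogen, the 6-chloro-1H-indol-3-yl group gives way to its ring-nitrogen counterpart with a 2.0-fold higher number from compound 3 to compound 4 (0.30 log units; within the scatter) in this assay. At this position, therefore, the chlorine and the carbon-only six-membered ring can both go without a shift beyond the scatter. Nothing available bears on why the two groups read alike.

The chlorine and the ring nitrogen change together here, leaving their separate contributions unresolved. A plain 1H-indol-3-yl group would separate the two.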